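From a Trimethoxyphenyl Limit to a Hydroxyphenyl Estimate

The source may hold more compounds than are shown below. What is called first, only, known or untested is meant among the compounds shown, and "the series" means these compounds.

compound 1, `CCN(CC)CCCn1c(=O)c(=Cc2cc(OC)c(OC)c(OC)c2)s/c1=C1\C(=O)Nc2ccc(C)cc21`, > 200000 nM
compound 2, `CCN(CC)CCCn1c(=O)c(=Cc2ccccc2O)s/c1=C1\C(=O)Nc2ccc(Br)cc21`, 19900 nM

In a functional assay on MDA-MB-231 cells (Homo sapiens) for inhibition, read by MTT assay, with a stated time of 72 h (on this read-out lower numbers stand for stronger inhibition and higher numbers for weaker inhibition), compound 1 reaches only a limit of the assay, > 200000 nM, and so sits at the limit of > 200000 nM in this assay, at which 1 of the 2 values shown sits, without a number of its own. In this assay, within the data shown here, compound 2 gives 19900 nM; it differs from compound 1 in more than one place, so the two values show only what each of them is, and no step between them can be told. Compound 3, `CCN(CC)CCCn1c(=O)c(=Cc2ccc(O)cc2)s/c1=C1\C(=O)Nc2ccc(C)cc21`, carries 4-hydroxyphenyl in place of 3,4,5-trimethoxyphenyl on a double-bonded chain carbon bound to an aromatic carbon. Among the measured compounds shown here, no measured step covers this change. The step is estimated at an at least 2.0-fold lower number from compound 1 to compound 3 (0.30 log units; that floor lies within the scatter), expected to stay weak. The estimate for compound 3 is 100000 nM, between 20000 nM and 300000 nM.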

Compound 3, half-maximal inhibitory concentration: 1810 nM
Compound 3: the middle estimate sits 55-fold (1.74 log units) above what was measured, outside the stated range (below it).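

In this assay, 4-hydroxyphenyl in place of 3,4,5-trimethoxyphenyl on a double-bonded chain carbon bound to an aromatic carbon gives an at least 110-fold lower number from compound 1 to compound 3 (2.04 log units; beyond the scatter), so on the core of compound 1 the group at this place can move the read-out far beyond the scatter. That step is a floor, and its full size stays unknown: the limit of > 200000 nM in this assay, at which 1 of the 3 values shown sits.

The compounds shown leave open whether the step follows the loss of the methoxy groups or the arrival of the hydroxyl, which 4-methoxyphenyl or plain phenyl on the same core could separate. Also open, from the compounds shown here alone, is how an amine or a carboxylic acid would fare in place of that hydroxyl.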